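This account rests on a few compounds, and the source may have more. Where it says the series, first, only, none or still open, it means among the compounds named here.

Compound 1 `COCCOc1cc(/C=C/c2ccc3ccccc3c2)ccc1OC` gives > 5000 nM in a functional assay on HCT-116 cells (Homo sapiens) for inhibition (a higher number here means a weaker inhibitor, a lower number a stronger inhibitor), which is a limit of the assay and not a number. Compound 2 `COc1ccc(/C=C/c2ccc3ccccc3c2)cc1[N+](=O)[O-]`, with a nitro group in place of the 2-methoxyethoxy group, gives > 5000 nM, and this too is a limit. Compound 2 therefore has no exact value, and it stands with compound 1 at the limit of > 5000 nM in this assay, at which 2 of the 2 values shown sit. For the measured compounds named here, the only measured change is a step that the two limits leave unreadable from compound 1 to compound 2, so no size can be carried forward from it.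

Compound 3 `COc1ccc(/C=C/c2ccc3ccccc3c2)cc1N` swaps the nitro group of compound 2 for an amino group on an aromatic carbon, ortho to a methoxy group: amino in place of nitro on an aromatic carbon. Going by the values given here, no measured step involves an amino group, so the expectation rests only on (the limit of > 5000 nM in this assay, at which 2 of the 2 values shown sit). Compound 3 is therefore expected to stay near that limit, with some room for a stronger result in this assay. The estimated change is a number no higher from compound 2 to compound 3 (the limit leaves the size open), and its true size remains uncertain. Compound 3 is estimated at 5000 nM, with an expected range from 1500 nM to 20000 nM.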

Compound 3, half-maximal inhibitory concentration: 1820 nM
Estimate against measurement, compound 3: 2.7-fold (0.44 log units) above; the range from low to high includes it.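

Amino at this position, ortho to a methoxy group, is the first change shown to move the read-out in this assay: amino in place of nitro gives an at least 2.7-fold lower number from compound 2 to compound 3 (0.43 log units; beyond the scatter), and the true size could be larger, as the starting point is a limit. Amino in place of 2-methoxyethoxy gives an at least 2.7-fold lower number from compound 1 to compound 3 (0.43 log units; beyond the scatter), so the change from either of two quite different groups ends at the same measured compound, and the result does not depend on nitro alone as the point of comparison. Compound 3 is also the only one of the three compounds with a measured number rather than a limit: the limit of > 5000 nM in this assay, at which 2 of the 3 values shown sit.

On these data alone, the steps from compound 3 back to the other two show only a minimum, and the step between those two cannot be read, so how far apart the three compounds truly lie stays unknown. As far as these compounds go, it also stays open whether the amino group itself matters or other groups would do as well at this position, such as a hydroxyl, a methylamino group or an acetamide.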